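From an Aryl Ketone to a Benzylamide

The source may report more compounds than this note shows. Statements on the series, on what has been measured and on what is new or still open speak of the compounds shown alone.

Compound 1 `COc1cc(-c2nnc(SCC(=O)c3ccc(F)c(F)c3)n2N)cc(OC)c1OC` is the anchor of this short series. Among the compounds with values here, in a functional assay on HCT-116 cells (Homo sapiens) for antiproliferative activity, read by MTT assay, with a stated time of 48 h (a higher number here means a weaker inhibitor, a lower number a stronger inhibitor), compound 1 gives 10400 nM, the only plain number among the values shown. Compound 2 `COc1cc(NC(=O)CSc2nnc(-c3cc(OC)c(OC)c(OC)c3)n2N)cc(OC)c1OC` returns > 100000 nM, which is a limit of the assay rather than a number (the limit of > 100000 nM in this assay, at which 1 of the 2 values shown sits). Compound 3 `COc1cc(-c2nnc(SCC(=O)NCc3ccc(C)cc3)n2N)cc(OC)c1OC` differs from compound 1 in one place: (4-methylbenzyl)amino in place of 3,4-difluorophenyl on a carbonyl carbon. Within the data shown here, no measured step of this kind exists, so the expectation rests on compound 1 alone. The expected step is a 2.9-fold higher number from compound 1 to compound 3 (0.46 log units; beyond the scatter) towards weaker inhibition. Compound 3 is therefore estimated at 30000 nM, within 8000 nM to 100000 nM.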

Compound 3, half-maximal inhibitory concentration: > 100000 nM
Compound 3 was reported as a limit; the forecaster's own chance of this, stated with the estimate: 30%; middle value at least 3.3-fold (0.52 log units) from the limit.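

Within the data shown here, the change from 3,4-difluorophenyl to (4-methylbenzyl)amino on the carbonyl carbon is the first single change that can be read, and in this assay it gives an at least 9.6-fold higher number from compound 1 to compound 3 (0.98 log units; beyond the scatter), towards weaker inhibition. The value of compound 3 is a limit and not a number, so the full size of this loss cannot be read. The series now has more compounds at the top of the range than with plain numbers: the limit of > 100000 nM in this assay, at which 2 of the 3 values shown sit.

Going by these compounds, it remains open whether an unsubstituted phenyl or a simple methylamino group on this carbonyl carbon would keep the activity of compound 1.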